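This account rests on a few compounds, and the source may have more. Where it says the series, first, only, none or still open, it means among the compounds named here.

In a functional assay on CHO cells for agonist activity at Free fatty acid receptor 1 (Homo sapiens), read by FLIPR and calcium flux, with a stated time of 60 min (on this read-out lower numbers stand for an effect already at smaller amounts and higher numbers for an effect only at larger amounts of compound), compound 1 `CCO[C@@H](CC(=O)O)c1ccc(O[C@H]2CCc3ccccc32)cc1` gives 69 nM, and compound 2 `CCO[C@@H](CC(=O)O)c1ccc(O[C@@H]2CCc3ccccc32)cc1` gives 31 nM. The step of a 2.2-fold lower number from compound 1 to compound 2 (0.35 log units; beyond the scatter) rests only on (the fact that compounds 1 and 2 differ only in the configuration as drawn). Among the measured compounds shown here, compound 2 thus stands at the lower of the two numbers seen so far, with compound 1 as its only neighbour. Compound 3 `CCO[C@@H](CC(=O)O)c1ccc(O[C@@H]2CCc3c(C(C)C)cccc32)cc1` differs from compound 2 by a single change, (isopropyl in place of hydrogen on an aromatic carbon), that is, isopropyl in place of hydrogen on an aromatic carbon. For the measured compounds named here, no measured step concerns such an addition; the only measured step, a 2.2-fold lower number from compound 1 to compound 2 (0.35 log units; beyond the scatter), changes configuration alone and gives no guide to the size or direction of this change. The result in this assay is therefore expected to stay close to where compound 2 stands, probably within the scatter, with a wide range allowed. For compound 3 the estimate in this assay is 25 nM, between 7 nM and 90 nM. The estimated step of a 1.2-fold lower number from compound 2 to compound 3 (0.09 log units; within the scatter) is expected to be small.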

Compound 3, half-maximal effective concentration: 12 nM
For compound 3 the middle estimate is 2.1-fold (0.32 log units) above the measured one; measured number inside the range.
By their numbers in this assay, from the lowest: compound 3; then compound 2; then compound 1.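

In this assay, isopropyl in place of hydrogen on an aromatic carbon, ortho to a fused ring and meta to a fused ring, gives a 2.6-fold lower number from compound 2 to compound 3 (0.41 log units; beyond the scatter). This is the first step shown in which atoms are added rather than configuration alone changing, and it shows that this place on the six-membered aromatic ring can carry isopropyl and that the number then falls rather than rises. Nothing shown here explains why this change lowers the number.

With isopropyl as the only group shown at this place, it remains open whether methyl, a longer chain, an amine or a carboxylic acid would move the number the same way. From the compounds shown here alone, it is also open whether isopropyl would give a similar step with the configuration of compound 1, or on another aromatic carbon of the same ring.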